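The source may report more compounds than this note shows. Statements on the series, on what has been measured and on what is new or still open speak of the compounds shown alone.

Compound 1 `Cc1c(C(=O)O)ccn1-c1ccccc1`: 3800 nM. Compound 2 `O=C(O)C1CCN(c2ccc(C(F)(F)F)cc2)C1`: 50000 nM. Compound 3 `O=C(O)C1CCN(c2ccc(Cl)c(Cl)c2)C1`: 1200 nM.

In an assay on cells for inhibition of Palmitoleoyl-protein carboxylesterase NOTUM variant C330S (Homo sapiens), read by fluorescence, with a stated time of 40 min (a lower number here means a stronger inhibitor, a higher number a weaker inhibitor), compound 3 gives the lowest of the three numbers. Compound 1 comes nearest with 3800 nM, a gap beyond the scatter. Compound 2 lies furthest away with 50000 nM, also beyond the scatter.

Compound 4 `O=C(O)C1CCN(c2ccc(C(F)(F)F)c(Cl)c2)C1` differs from compound 3 in one place: trifluoromethyl in place of chloro on an aromatic carbon. Among the measured compounds shown here, no pair among the measured compounds isolates this change. Compound 2 carries a trifluoromethyl without any chloro and gives 50000 nM, the weakest value recorded, whereas compound 3 with two chloro groups gives 1200 nM. On that basis compound 4 is expected to be a weaker inhibitor than compound 3, with an estimated step of a 3.3-fold higher number from compound 3 to compound 4 (0.52 log units; beyond the scatter) in this assay. Compound 4 is estimated at 4000 nM, within a range from 1200 nM to 15000 nM.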

Compound 4, half-maximal inhibitory concentration: 8500 nM
Estimate against measurement, compound 4: 2.1-fold (0.33 log units) below, and the stated range covers the measured number.
By their numbers in this assay, from the lowest: compound 3; then compound 1; then compound 4; then compound 2.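

In this assay, the position para to a group of 8 heavy atoms now has a direct comparison: trifluoromethyl in place of chloro gives a 7.1-fold higher number from compound 3 to compound 4 (0.85 log units; beyond the scatter). Chloro in place of hydrogen on an aromatic carbon, with the trifluoromethyl kept, moves the other way and gives a 5.9-fold lower number from compound 2 to compound 4 (0.77 log units; beyond the scatter), so the two changes on this aromatic ring can now be read separately. The data offer no explanation for either step. As far as these compounds go, it remains open how a methyl, a methoxy or a nitrile in place of the trifluoromethyl would compare with chloro at this position.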